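Working notes: fluoro on the phenethyl group

A few compounds are considered here, and "the series" means these few. Any claim that something is new, unique, unknown or untested is made for them only; others in the source may bear on it.

Values in an ADME assay on the whole organism for metabolic stability, with Rattus norvegicus as the target; a higher number here means faster removal of the compound, a lower number slower removal:
- compound 1 `COc1cccc(CNC(=O)c2nc3cccc(OCCc4ccccc4)c3c(=O)[nH]2)c1`: 28.3 mL/min/kg
- compound 2 `COc1cccc(CNC(=O)c2nc3ccc(F)c(OCCc4ccccc4)c3c(=O)[nH]2)c1`: 16.7 mL/min/kg

Only these two numbers exist so far, and the number for compound 2 lies within the scatter of the number for compound 1. Compound 3 `COc1cccc(CNC(=O)c2nc3ccc(F)c(OCCc4ccc(F)cc4)c3c(=O)[nH]2)c1` has not yet been measured. It differs from compound 2 by fluoro in place of hydrogen on an aromatic carbon, which turns phenethyl into 2-(4-fluorophenyl)ethyl. Among the measured compounds shown here, the one measured step of the same kind, fluoro in place of hydrogen on an aromatic carbon, is a 1.7-fold lower number from compound 1 to compound 2 (0.23 log units; within the scatter). That step lies within the scatter and sits on the shared core, not on the ring that changes here, so it offers only weak guidance. No step beyond the scatter is therefore expected in this assay, and the estimate is a 1.0-fold lower number from compound 2 to compound 3 (0.02 log units; within the scatter). For compound 3 the expected value is 16 mL/min/kg, with an estimated range of 9 mL/min/kg to 29 mL/min/kg.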

Compound 3, clearance: 28.3 mL/min/kg
Estimate against measurement, compound 3: 1.8-fold (0.25 log units) below; the measured number falls inside the stated range.
By their numbers in this assay, from the lowest: compounds 2, 1 and 3 (each within the scatter of the next).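

Fluoro in place of hydrogen on the phenethyl ring, para to a large group, gives a 1.7-fold higher number from compound 2 to compound 3 (0.23 log units; within the scatter) in this assay. Phenethyl and 2-(4-fluorophenyl)ethyl therefore cannot be told apart by clearance at this position, and this is the first reading on that ring rather than on the shared core. Neither this step nor a 1.7-fold lower number from compound 1 to compound 2 (0.23 log units; within the scatter) lies beyond the scatter, so no fluoro step shown here has a readable effect, and nothing available bears on the reason for this reading.

Open, from the compounds shown here alone, is whether a larger group at this position, such as trifluoromethyl or methoxy, would give a step beyond the scatter. Also open, going by these compounds, is whether a longer chain in place of the ethyl link would do so.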